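The source may hold more compounds than are shown below. What is called first, only, known or untested is meant among the compounds shown, and "the series" means these compounds.

In an ADME assay on the whole organism for metabolic stability, with Rattus norvegicus as the target (a higher number here means that the compound lasts longer, a lower number that the compound disappears faster), compound 1 `CSCC[C@H](NC(=O)c1ccc(CN(Cc2ccccc2)c2cccnc2)cc1-c1ccccc1C)C(=O)O` gives 0.83 h and compound 2 `CSCC[C@H](NC(=O)c1ccc(CN(Cc2ccccc2)c2ccccc2)cc1-c1ccccc1C)C(=O)O` gives 0.8 h. The pair lies within the scatter, with a 1.0-fold lower number from compound 1 to compound 2 (0.02 log units; within the scatter), so phenyl in place of pyridin-3-yl on the amine nitrogen shows no measurable effect here.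

Compound 3 `CSCC[C@H](NC(=O)c1ccc(CN(Cc2ccccc2)c2cncc(F)c2)cc1-c1ccccc1C)C(=O)O` is reported only as a limit, < 0.4 h. Within the data shown here, its fluoro substituent marks the one step beyond the scatter, an at least 2.0-fold lower number from compound 1 to compound 3 (0.31 log units; beyond the scatter). The comparison with the phenyl analogue gives an at least 2.0-fold lower number from compound 2 to compound 3 (0.30 log units; that floor lies within the scatter), a floor that stays within the scatter.

Compound 4 `CSCC[C@H](NC(=O)c1ccc(CN(Cc2ccccc2)c2cncnc2)cc1-c1ccccc1C)C(=O)O` has not yet been measured. It differs from compound 3 by pyrimidin-5-yl in place of 5-fluoropyridin-3-yl on an amine nitrogen, with pyrimidin-5-yl in place of 5-fluoropyridin-3-yl on an amine nitrogen. Among the measured compounds shown here, the fluoro substituent therefore leaves, and no measured compound carries the pyrimidin-5-yl group, so the expectation remains loose.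

With the fluoro gone, a return towards compound 1 at 0.83 h is expected, though perhaps not all the way. The expected change is modest and upward, an at least 1.6-fold higher number from compound 3 to compound 4 (0.21 log units; that floor lies within the scatter). For compound 4 the estimated half-life is 0.65 h, with an expected range from 0.3 h to 1.3 h.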

Compound 4, half-life: 0.5 h
Estimate against measurement, compound 4: 1.3-fold (0.11 log units) above, and the stated range covers the measured number.
By their numbers in this assay, from the lowest: compounds 4, 2 and 1 (each within the scatter of the next). At a limit, below all of these: compound 3.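

In this assay, the pyrimidin-5-yl group on the amine nitrogen does not separate compound 4 from the phenyl analogue (a 1.6-fold lower number from compound 2 to compound 4 (0.20 log units; within the scatter)) or from the pyridin-3-yl analogue (a 1.7-fold lower number from compound 1 to compound 4 (0.22 log units; within the scatter)). Across these three unfluorinated compounds, the half-life therefore tolerates all three rings on the amine nitrogen, and compound 3, with its 5-fluoropyridin-3-yl group, is the one compound that may go against this picture. Compound 4 does not settle that exception, and the step to it is only a floor within the scatter (an at least 1.2-fold higher number from compound 3 to compound 4 (0.09 log units; that floor lies within the scatter)), resting on the limit reported for compound 3: the limit of < 0.4 h in this assay, at which 1 of the 4 values shown sits.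

As far as these compounds go, how far compound 3 truly lies from compound 4 stays open, as does whether a chloro, methyl or nitrile group in place of the fluoro on the pyridine ring would behave like compound 3 or like compound 1. Also open, from the compounds shown here alone, is whether the half-life would respond more clearly to a change away from the amine nitrogen, such as an ester or an amide in place of the carboxylic acid.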